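The source may hold more compounds than are shown below. What is called first, only, known or untested is meant among the compounds shown, and "the series" means these compounds.

Measured in a functional assay on MCF7 cells (Homo sapiens) for antiproliferative activity, read by CCK-8 assay, with a stated time of 72 h; a lower number here means a stronger inhibitor of growth, a higher number a weaker inhibitor of growth:
- compound 1 `CCCNS(=O)(=O)c1ccc(Nc2ncc3c(n2)N(c2ccn(C)n2)C(CC)C(=O)N3C)cc1`: 3000 nM
- compound 2 `CCC1C(=O)N(C)c2cnc(-n3ccc4cc(F)ccc43)nc2N1c1ccn(C)n1`: 24700 nM

In this assay compound 1 gives 3000 nM and compound 2 gives 24700 nM, the higher of the two numbers. The gap between these two compounds lies beyond the scatter. Compound 3 `CCC1C(=O)N(C)c2cnc(-n3ccc4cc(C(=O)NCC(C)C)ccc43)nc2N1c1ccn(C)n1` has isobutylcarbamoyl in place of fluoro on an aromatic carbon. Within the data shown here, no measured step bears on this change, so the expectation is only tentative. A moderate move to a stronger inhibitor of growth is expected, an estimated 3.1-fold lower number from compound 2 to compound 3 (0.49 log units; beyond the scatter), though a step within the scatter remains possible. Compound 3 is estimated at 8000 nM, with an expected range from 1800 nM to 30000 nM.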

Compound 3, concentration for 50% growth inhibition: 4810 nM
Beside the measured number, compound 3's estimate is 1.7-fold (0.22 log units) above it; low and high end bracket the measured number.
By their numbers in this assay, from the lowest: compounds 1 and 3 (each within the scatter of the next); then compound 2.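

On an aromatic carbon of the six-membered carbon ring, meta to a fused ring and para to a fused ring, replacing fluoro with isobutylcarbamoyl gives a 5.1-fold lower number from compound 2 to compound 3 (0.71 log units; beyond the scatter) in this assay, a step beyond the scatter. This position therefore accepts a far larger substituent carrying an amide without any loss of growth inhibition. No measurement available here accounts for the step.

On these data alone, it remains open whether the carbonyl, the amide hydrogen or the isobutyl chain carries the change. A carboxylic acid, a primary amide or a longer chain on the amide at this carbon would help separate these.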